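A few compounds are considered here, and "the series" means these few. Any claim that something is new, unique, unknown or untested is made for them only; others in the source may bear on it.

Measured compounds:
compound 1 `COc1ccc(C(=O)Nc2cccc(-c3oc4cc(-c5ccc(F)cc5)ccc4c(=O)c3O)c2)cc1` – 21100 nM
compound 2 `COc1cccc(C(=O)Nc2cccc(-c3oc4cc(-c5ccc(F)cc5)ccc4c(=O)c3O)c2)c1` – 12500 nM

Among the measured compounds shown here, in a functional assay on GTL 16 cells for antiproliferative activity against GTL 16 cell line (Homo sapiens), read by CCK-8 assay, with a stated time of 72 h (a lower number here means a stronger inhibitor, a higher number a weaker inhibitor), compound 2 gives 12500 nM, and its only neighbour in the set is compound 1 with 21100 nM. For the measured compounds named here, the step of a 1.7-fold lower number from compound 1 to compound 2 (0.23 log units; within the scatter) is the one comparison available, and it does not separate the two compounds beyond the scatter of repeated measurements.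

Compound 3 `CCc1ccc(C(=O)Nc2cccc(-c3oc4cc(-c5ccc(F)cc5)ccc4c(=O)c3O)c2)cc1` has not yet been measured. It differs from compound 2 as follows: 4-ethylphenyl in place of 3-methoxyphenyl on a carbonyl carbon. Going by the values given here, the one measured step concerns the same carbonyl-bound ring, and it was small, so it offers no ground for expecting a change beyond the scatter from this second exchange at the same place. Compound 3 is therefore expected to sit close to compound 2, with a step of a 1.0-fold lower number from compound 2 to compound 3 (0.02 log units; within the scatter) in this assay. The estimate for compound 3 is 12000 nM, within a range from 5000 nM to 30000 nM.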

Compound 3, half-maximal inhibitory concentration: 24600 nM
Beside the measured number, compound 3's estimate is 2.1-fold (0.31 log units) below it; low and high end bracket the measured number.
By their numbers in this assay, from the lowest: compounds 2, 1 and 3 (each within the scatter of the next).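

With compound 3, the ring on the carbonyl carbon carries a group with no oxygen and no hydrogen-bond acceptor, yet in this assay the exchange of ethyl for methoxy on an aromatic carbon gives only a 1.2-fold higher number from compound 1 to compound 3 (0.07 log units; within the scatter) and the exchange of 3-methoxyphenyl for 4-ethylphenyl gives a 2.0-fold higher number from compound 2 to compound 3 (0.29 log units; within the scatter). At this position, therefore, the numbers give no sign that the oxygen of the methoxy group matters, and all three compounds stay within the scatter of one another. No evidence is at hand that bears on these numbers.

From the compounds shown here alone, whether an amine, a carboxylic acid or a longer alkyl chain on this ring would move the number beyond the scatter stays open. So does whether any group at this place can give a much lower number than these three.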